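From Chlorophenyl to Methoxy: An Expected Loss of Potency

The compounds below may be only part of what the source reports. "The series", "measured", "known", "first", "only" and "open" are said of these compounds alone.

Compound 1 `Nc1ncnc2c1ncn2C[C@@H]1C[C@H](CO)c2ccccc21`: 24 ug/mL
Compound 2 `OC[C@H]1C[C@@H](Cn2cnc3c(-c4ccc(Cl)cc4)ncnc32)c2ccccc21`: 0.63 ug/mL
Compound 3 `Cn1ncc2c1[C@H](Cn1cnc3c(Cl)nc(N)nc31)C[C@@H]2CO`: 3.2 ug/mL

In a functional assay on MOLT-4 cells (Homo sapiens) (on this read-out lower numbers stand for stronger inhibition and higher numbers for weaker inhibition), compound 2 gives the lowest of the three numbers; compound 3 gives a higher number and compound 1 the highest, both gaps being beyond the scatter. Compound 4 `COc1ncnc2c1ncn2C[C@@H]1C[C@H](CO)c2ccccc21` differs from compound 2 in one place: methoxy in place of 4-chlorophenyl on an aromatic carbon. Among the measured compounds shown here, the one step that bears on this is a 38-fold lower number from compound 1 to compound 2 (1.58 log units; beyond the scatter), where a 4-chlorophenyl group entered in place of amino. Compound 4 again lacks the 4-chlorophenyl group, carrying a small substituent instead, so a large step in the opposite direction is expected in this assay, roughly back toward compound 1. Compound 4 is therefore estimated at 15 ug/mL, within 4 ug/mL to 50 ug/mL, which means an expected 24-fold higher number from compound 2 to compound 4 (1.38 log units; beyond the scatter).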

Compound 4, half-maximal inhibitory concentration: 24 ug/mL
Estimate against measurement, compound 4: 1.6-fold (0.20 log units) below, and the stated range covers the measured number.
By their numbers in this assay, from the lowest: compound 2; then compound 3; then compounds 1 and 4 (each within the scatter of the next).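

In this assay the exchange gives a 38-fold higher number from compound 2 to compound 4 (1.58 log units; beyond the scatter) and so removes the whole gain seen with the 4-chlorophenyl group, this time with methoxy rather than amino as the replacement. Methoxy and amino do not separate at this aromatic carbon, with no change at the digits printed from compound 1 to compound 4 (within the scatter) and only the 4-chlorophenyl compound standing apart among these three. No measured evidence is available to explain this difference. The compounds shown leave open whether a plain phenyl group without the chlorine would retain the low number. They also leave open whether a morpholine or a longer alkyl chain here would behave like 4-chlorophenyl or like methoxy.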